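Moving methoxy groups on the amide-linked aryl ring

This account rests on a few compounds, and the source may have more. Where it says the series, first, only, none or still open, it means among the compounds named here.

Compound 1 `COc1cc(C(=O)Nc2ccc(C(=O)/C=C/c3nc(C)c(C)nc3C)cc2)cc(OC)c1OC` and compound 2 `COc1ccc(C(=O)Nc2ccc(C(=O)/C=C/c3nc(C)c(C)nc3C)cc2)cc1` share a core and differ only in the aromatic ring attached to the amide carbonyl. In a functional assay on MCF7 cells (Homo sapiens) for antiproliferative activity, read by CCK-8 assay, with a stated time of 72 h (on this read-out higher numbers stand for weaker inhibition and lower numbers for stronger inhibition), compound 1 gives 2760 nM. In this assay compound 2 gives 1410 nM. These two figures lie within the usual scatter of repeated measurements of each other, so compound 2 cannot be called a stronger inhibitor than compound 1 on these numbers; it simply stands beside compound 1.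

Compound 3 `COc1cc(OC)cc(C(=O)Nc2ccc(C(=O)/C=C/c3nc(C)c(C)nc3C)cc2)c1` has not yet been measured. It differs from compound 2 in one place: 3,5-dimethoxyphenyl in place of 4-methoxyphenyl on a carbonyl carbon. Among the measured compounds shown here, no measured pair in this set isolates such a change, so there is no directly comparable step to lean on. For the measured compounds named here, with only two values known, and those close together, the expectation is that compound 3 stays near compound 2, with any move in this assay expected to be small, perhaps toward a slightly higher number, and not clearly beyond the scatter. Compound 3 is therefore estimated at 1800 nM, within a range from 600 nM to 5500 nM. That estimate means an expected step of a 1.3-fold higher number from compound 2 to compound 3 (0.11 log units; within the scatter).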

Compound 3, half-maximal inhibitory concentration: 6270 nM
Beside the measured number, compound 3's estimate is 3.5-fold (0.54 log units) below it; measured number above the stated range.
By their numbers in this assay, from the lowest: compounds 2 and 1 (each within the scatter of the next); then compound 3.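

In this assay, among the compounds shown here, 3,5-dimethoxyphenyl in place of 4-methoxyphenyl on the carbonyl carbon gives a 4.4-fold higher number from compound 2 to compound 3 (0.65 log units; beyond the scatter), the first clear evidence that inhibition depends on what this aromatic ring carries. Hydrogen in place of methoxy on an aromatic carbon gives a 2.3-fold higher number from compound 1 to compound 3 (0.36 log units; beyond the scatter), so losing that single methoxy group from the ring of compound 1 also weakens inhibition; among these three compounds, the two that keep the methoxy group found in 4-methoxyphenyl have the lower numbers, and compound 3, which lacks it, has the highest, although the count of methoxy groups alone does not set the order, since compound 1 and compound 2 lie within the scatter of each other. Nothing shown here explains why the loss of this group weakens inhibition.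

The compounds shown leave open whether a methoxy group is specifically needed at that ring position, or whether a hydroxyl group, a chlorine atom or a dimethylamino group could serve there equally well. They also leave open how a plain phenyl ring, with no methoxy groups at all, would compare.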